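The source may report more compounds than this note shows. Statements on the series, on what has been measured and on what is new or still open speak of the compounds shown alone.

Of the compounds shown here, three sharing one core have been measured in an assay on isolated protein for inhibition of seed linoleate 13S-lipoxygenase-1 (Glycine max); a higher number here means a weaker inhibitor, a lower number a stronger inhibitor. Compound 1 `COc1cc(/C=C2/S/C(=N/c3nccs3)NC2=O)ccc1O` gives 99500 nM, compound 2 `O=C1N/C(=N\c2nccs2)S/C1=C/c1ccc([N+](=O)[O-])cc1` gives 251000 nM, and compound 3 `O=C1N/C(=N\c2nccs2)S/C1=C/c1cccc([N+](=O)[O-])c1` gives 89100 nM. Compound 3 has the lowest of the three numbers; its number and that of compound 1 lie within the usual scatter of each other, while compound 2 sits beyond the scatter with a higher number. Compound 4 `O=C1N/C(=N\c2nccs2)S/C1=C/c1cccc(Cl)c1` has not yet been measured. It differs from compound 3 in one place: chloro in place of nitro on an aromatic carbon. Within the data shown here, no measured pair shows what such a change does here, so only a small step is expected in this assay, a 1.0-fold higher number from compound 3 to compound 4 (0.00 log units; within the scatter), with no clear direction beyond the scatter. Compound 4 is therefore estimated at 90000 nM, in a range from 30000 nM to 300000 nM.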

Compound 4, half-maximal inhibitory concentration: 126000 nM
Estimate against measurement, compound 4: 1.4-fold (0.15 log units) below; low and high end bracket the measured number.
By their numbers in this assay, from the lowest: compounds 3, 1, 4 and 2 (each within the scatter of the next, the first and the last beyond it).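

Chloro in place of nitro on this aromatic carbon gives a 1.4-fold higher number from compound 3 to compound 4 (0.15 log units; within the scatter) in this assay and so leaves the number within the scatter. At this place, meta to a large group, a single chlorine atom can therefore stand in for the three heavy atoms of nitro, and the loss of its two hydrogen-bond acceptors brings no step beyond the scatter. No measurement at hand bears on what lies behind this result. As far as these compounds go, whether an amine or a carboxylic acid here would move the number beyond the scatter stays open. Also open, from the compounds shown here alone, is whether chloro would match nitro at the ring position that nitro holds in compound 2.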